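The compounds below may be only part of what the source reports. "The series", "measured", "known", "first", "only" and "open" are said of these compounds alone.

Compound 3 `Clc1cncc(C2=CC3CNCC(C2)C3)c1` carries a chloro group on the six-membered aromatic ring with one nitrogen and a hydrogen on the amine nitrogen in the ring; in an in vitro assay on SH-SY5Y cells for displacement of a labelled ligand from Neuronal acetylcholine receptor; alpha3/beta4 (Homo sapiens) (a lower number here means a stronger inhibitor, a higher number a weaker inhibitor), compound 3 gives 40 nM. Compound 2 `CN1CC2C=C(c3cncc(Cl)c3)CC(C2)C1` is the methyl-bearing counterpart and in this assay compound 2 gives 1830 nM; the step is a 46-fold lower number from compound 2 to compound 3 (1.66 log units; beyond the scatter). Compound 1 `Clc1cccc(Oc2cncc(C3=CC4CNCC(C3)C4)c2)c1` in this assay gives 22 nM. Among the three numbers compound 3 stands second highest, nearest to compound 1 and furthest from compound 2.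

Compound 4 `FC(F)(F)c1cncc(C2=CC3CNCC(C2)C3)c1` differs from compound 3 by trifluoromethyl in place of chloro on an aromatic carbon. Among the compounds with values here, no measured step changes the substituent on this aromatic carbon while keeping the rest fixed: the only measured step concerns the amine nitrogen and has no bearing on the aromatic substituent. Compound 1 and compound 3, which differ only at this position, show values within the scatter of each other, so the position tolerates a change from chloro to a much larger group without a shift beyond the scatter. A step of a 1.4-fold higher number from compound 3 to compound 4 (0.14 log units; within the scatter) is therefore expected, lying within the scatter. In this assay compound 4 is estimated at 55 nM, with a range from 18 nM to 170 nM.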

Compound 4, inhibition constant: 79 nM
Compound 4: middle estimate off by 1.4-fold (0.16 log units), on the low side; low and high end bracket the measured number.
By their numbers in this assay, from the lowest: compounds 1, 3 and 4 (each within the scatter of the next, the first and the last beyond it); then compound 2.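

In this assay the replacement of chloro by trifluoromethyl, with one heavy atom giving way to four, amounts to a 2.0-fold higher number from compound 3 to compound 4 (0.30 log units; within the scatter) and adds a second replacement of chloro at this aromatic carbon whose value stays within the scatter of compound 3, this time with a group that has no ring. The two replacements are still not interchangeable: compound 1 at 22 nM and compound 4 at 79 nM lie beyond the scatter of each other, although each lies within the scatter of compound 3. No measurement at hand gives a reason for either reading at this position.

Whether the position also accepts an amine, a carboxylic acid or a nitrile on this aromatic carbon remains open, since all the groups shown there so far carry no hydrogen-bond donor and the reading for such groups cannot be taken from chloro and trifluoromethyl. Also open is whether the large step on the amine nitrogen, a 46-fold lower number from compound 2 to compound 3 (1.66 log units; beyond the scatter), holds with trifluoromethyl in place of chloro, as the methyl-bearing counterpart of compound 4 is not among the compounds shown.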